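The source may hold more compounds than are shown below. What is called first, only, known or untested is meant among the compounds shown, and "the series" means these compounds.

Of the compounds shown here, three have been measured and a fourth has not. Compound 1 `CO[C@@H]1[C@H](N(C)c2ncc(-c3c[nH]c4ccc(Cl)cc34)s2)C[C@H]2O[C@]1(C)n1c3ccccc3c3c4c(c5c6ccccc6n2c5c31)C(=O)NC4` carries a chloro group, compound 2 `CO[C@@H]1[C@H](N(C)c2ncc(-c3c[nH]c4ccc(Br)cc34)s2)C[C@H]2O[C@]1(C)n1c3ccccc3c3c4c(c5c6ccccc6n2c5c31)C(=O)NC4` has a bromo group in its place, and compound 3 `CO[C@@H]1[C@H](N(C)c2ncc(-c3c[nH]c4ccc(Cl)cc34)s2)C[C@H]2O[C@]1(C)n1c3ccccc3c3c4c(c5c6cc(Br)ccc6n2c5c31)C(=O)NC4` keeps the chloro group of compound 1 but carries an extra bromo group on its core. In a functional assay on MV4-11 cells (Homo sapiens) for antiproliferative activity, read by CellTiter-Glo, with a stated time of 72 h (on this read-out higher numbers stand for weaker inhibition and lower numbers for stronger inhibition), compound 1 gives 420 nM. In this assay compound 2 gives 410 nM. In this assay compound 3 gives 700 nM.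

The change from compound 1 to compound 2 is bromo in place of chloro on an aromatic carbon, and it made a step of a 1.0-fold lower number from compound 1 to compound 2 (0.01 log units; within the scatter). The cores of compound 1 and compound 3 differ by bromo in place of hydrogen on an aromatic carbon, and that step was a 1.7-fold higher number from compound 1 to compound 3 (0.22 log units; within the scatter).

Compound 4 `CO[C@@H]1[C@H](N(C)c2ncc(-c3c[nH]c4ccc(Br)cc34)s2)C[C@H]2O[C@]1(C)n1c3ccccc3c3c4c(c5c6cc(Br)ccc6n2c5c31)C(=O)NC4` has not been measured. It differs from compound 3 by bromo in place of chloro on an aromatic carbon. The place of this change is described in the same words as the place of the change from compound 1 to compound 2, so it is the same change, now made on the core of compound 3 instead of the core of compound 1.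

The step from compound 3 to compound 4 is expected to be about no change at the digits printed from compound 3 to compound 4 (within the scatter), beside a 1.0-fold lower number from compound 1 to compound 2 (0.01 log units; within the scatter), because the same change on compound 1 gave a 1.0-fold lower number from compound 1 to compound 2 (0.01 log units; within the scatter). On that basis compound 4 is estimated to give 700 nM in this assay, most likely between 350 nM and 1400 nM.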

Compound 4, half-maximal inhibitory concentration: 390 nM
Compound 4: the middle estimate sits 1.8-fold (0.25 log units) above what was measured, and the stated range covers the measured number.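

The swap of 5-chloro-1H-indol-3-yl for 5-bromo-1H-indol-3-yl made a 1.8-fold lower number from compound 3 to compound 4 (0.25 log units; within the scatter) in this assay, and this step does not differ from the earlier one by more than the usual scatter: the same change on two cores in this assay, a 1.0-fold lower number (0.01 log units; within the scatter) from compound 1 to compound 2 and a 1.8-fold lower number (0.25 log units; within the scatter) from compound 3 to compound 4, 1.8-fold (0.24 log units) apart, within the scatter of two such steps

The extra bromo group on the core, now read with the bromo group already in place of the chloro, made a 1.1-fold lower number from compound 2 to compound 4 (0.02 log units; within the scatter), and this change also carries over within the scatter: the same change on two cores in this assay, a 1.7-fold higher number (0.22 log units; within the scatter) from compound 1 to compound 3 and a 1.1-fold lower number (0.02 log units; within the scatter) from compound 2 to compound 4, 1.8-fold (0.24 log units) apart, within the scatter of two such steps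

So across these four compounds, each change behaves alike on both cores, but every step is small enough to be lost in the scatter, which means the data show only that neither change moved the number measurably here, not that the two changes would carry over in the same way to any other core in the series.

The compounds shown hold only chloro or bromo at the place of the swap, so it stays open whether a group of another kind there, such as a methoxy group, a nitrile or an amine, would also leave the number within the scatter. Going by these compounds, whether any larger step would carry from core to core as these small ones do also stays open.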